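The source may hold more compounds than are shown below. What is called first, only, known or untested is meant among the compounds shown, and "the series" means these compounds.

Measured so far in the compounds shown:
compound 1 `COc1ncnc2c1c(-c1ccoc1)cn2[C@@H]1O[C@H](CO)[C@@H](O)[C@H]1O`: 290 nM
compound 2 `COc1ncnc2c1c(-c1cccs1)cn2[C@@H]1O[C@H](CO)[C@@H](O)[C@H]1O`: 13900 nM
compound 3 `CSc1ncnc2c1c(-c1ccoc1)cn2[C@@H]1O[C@H](CO)[C@@H](O)[C@H]1O`: a limit, > 15000 nM

All three were tested in a functional assay on HepG2 cells (Homo sapiens) for antiproliferative activity, read by XTT assay, with a stated time of 72 h; a higher number here means a weaker inhibitor, a lower number a stronger inhibitor. Compound 1 gives 290 nM. Exchanging thiophen-2-yl in place of furan-3-yl on an aromatic carbon weakens it: a 48-fold higher number from compound 1 to compound 2 (1.68 log units; beyond the scatter). The other exchange from compound 1, (methylsulfanyl in place of methoxy on an aromatic carbon), also weakens it: an at least 51-fold higher number from compound 1 to compound 3 (1.71 log units; beyond the scatter). For compound 3 the result is only a limit, (the limit of > 15000 nM in this assay, at which 1 of the 3 values shown sits), so its true value is not known.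

Compound 4 `CSc1ncnc2c1c(-c1cccs1)cn2[C@@H]1O[C@H](CO)[C@@H](O)[C@H]1O` is not yet measured. It differs from compound 3 by thiophen-2-yl in place of furan-3-yl on an aromatic carbon, the same change as from compound 1 to compound 2, at the same place. For compound 3 the step is expected to be a step that the limit leaves unreadable from compound 3 to compound 4, resting on compound 1 and its step of a 48-fold higher number from compound 1 to compound 2 (1.68 log units; beyond the scatter). Compound 4 is therefore expected to give about 100000 nM, between 15000 nM and 700000 nM, most likely again only a limit.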

Compound 4, half-maximal inhibitory concentration: > 20000 nM
Compound 4: no number, only a limit; the forecaster's own chance of this, stated with the estimate: 95%; the middle value lies beyond the limit too.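

In this assay compound 4 gives only a limit, > 20000 nM. On the thiophen-2-yl compounds, methylsulfanyl in place of methoxy gives only a floor, an at least 1.4-fold higher number from compound 2 to compound 4 (0.15 log units; that floor lies within the scatter), and the step between the two limits cannot be read, so neither measurement gives the true size of a change. The data therefore neither show that the methylsulfanyl exchange has the same size on both cores nor show that its size differs: the same change on two cores in this assay, an at least 51-fold higher number (1.71 log units; beyond the scatter) from compound 1 to compound 3 and an at least 1.4-fold higher number (0.15 log units; that floor lies within the scatter) from compound 2 to compound 4; the limit leaves it open whether they differ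

The compounds shown leave open how far the loss seen with methylsulfanyl depends on the ring it is paired with. They also leave open how an amine or an ethoxy group in place of methoxy would read alongside furan-3-yl.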